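Sulfonamide aryl variation: thiophen-2-yl replacing 2-chlorophenyl

The source may report more compounds than this note shows. Statements on the series, on what has been measured and on what is new or still open speak of the compounds shown alone.

Measured so far in a functional assay on MDA-MB-231 cells (Homo sapiens) for antiproliferative activity, read by MTT assay, with a stated time of 72 h; on this read-out lower numbers stand for stronger inhibition and higher numbers for weaker inhibition:
- compound 1 `CCOC(=O)c1oc2ccc(NS(=O)(=O)c3ccc(Cl)cc3)cc2c1C`: 53900 nM
- compound 2 `CCOC(=O)c1oc2ccc(NS(=O)(=O)c3cccc(Cl)c3)cc2c1C`: 57300 nM
- compound 3 `CCOC(=O)c1oc2ccc(NS(=O)(=O)c3ccccc3Cl)cc2c1C`: > 200000 nM, which is a limit of this assay and not a number

Compound 3 therefore stands at the top of the shown range: its value is only the limit (the limit of > 200000 nM in this assay, at which 1 of the 3 values shown sits). The steps leading to it are an at least 3.7-fold higher number from compound 1 to compound 3 (0.56 log units; beyond the scatter) and an at least 3.4-fold higher number from compound 2 to compound 3 (0.54 log units; beyond the scatter), both beyond the scatter, whereas a 1.1-fold higher number from compound 1 to compound 2 (0.03 log units; within the scatter) stays within the scatter. Thus 3-chlorophenyl and 4-chlorophenyl on the sulfonyl sulfur give similar numbers, and 2-chlorophenyl gives a clearly higher one.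

Compound 4 `CCOC(=O)c1oc2ccc(NS(=O)(=O)c3cccs3)cc2c1C` differs from compound 3 by thiophen-2-yl in place of 2-chlorophenyl on a sulfonyl sulfur. Among the compounds with values here, none of the measured steps covers this change; the only bearing evidence is that leaving 2-chlorophenyl for another aryl group (compounds 1 and 2) gave at least modest lower numbers in this assay. Whether a five-membered ring without the chlorine behaves like those two or like compound 3 is not shown.

For compound 4 a step of an at least 2.2-fold lower number from compound 3 to compound 4 (0.34 log units; beyond the scatter) toward lower numbers is expected, with a real chance that only a limit is again reported. The estimate for compound 4 in this assay is 90000 nM, between 35000 nM and 200000 nM.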

Compound 4, half-maximal inhibitory concentration: 44100 nM
Estimate against measurement, compound 4: 2.0-fold (0.31 log units) above; low and high end bracket the measured number.
By their numbers in this assay, from the lowest: compounds 4, 1 and 2 (each within the scatter of the next). At a limit, above all of these: compound 3.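

In this assay, thiophen-2-yl in place of 2-chlorophenyl on the sulfonyl sulfur gives an at least 4.5-fold lower number from compound 3 to compound 4 (0.65 log units; beyond the scatter), the first change shown that leaves the aryl group without chlorine altogether.

The reading for compound 3 remains a limit and not a number, so the true size of this step stays unknown: the limit of > 200000 nM in this assay, at which 1 of the 4 values shown sits.

Against the other two aryl groups, thiophen-2-yl gives a 1.3-fold lower number from compound 2 to compound 4 (0.11 log units; within the scatter) and a 1.2-fold lower number from compound 1 to compound 4 (0.09 log units; within the scatter), so a five-membered aromatic ring with one hetero atom reads alike with 3-chlorophenyl and 4-chlorophenyl at this place, chlorine is not required for numbers at this level, and among the aryl groups shown only 2-chlorophenyl stands apart.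

Open, as far as these compounds go, is whether the loss seen with 2-chlorophenyl belongs to chlorine itself or would recur with a methyl or methoxy group in its place, and whether plain phenyl or thiophen-3-yl would read with compounds 1, 2 and 4. Also open, from the compounds shown here alone, is whether anything on the sulfonyl side can move the numbers beyond the scatter of this group, and how a carboxylic acid or an amide in place of the ester on the shared core would read.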